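This account rests on a few compounds, and the source may have more. Where it says the series, first, only, none or still open, it means among the compounds named here.

Among the compounds with values here, in a functional assay on MDA-MB-231 cells (Homo sapiens) for inhibition, read by MTT assay, with a stated time of 48 h (a lower number here means a stronger inhibitor, a higher number a weaker inhibitor), compound 2 `COc1ccc(-c2cc(-c3cc(OC)c(OC)c(OC)c3)nc(-c3ccccc3)n2)cc1` gives 3390 nM and stands within the scatter of compound 1 `COc1cc(-c2cc(-c3ccc(C)cc3)nc(-c3ccccc3)n2)cc(OC)c1OC` at 5110 nM on the only two numbers so far. Going to compound 3 `COc1cc(-c2cc(-c3cccc4ccccc34)nc(-c3ccccc3)n2)cc(OC)c1OC` brings naphthalen-1-yl in place of 4-methoxyphenyl on an aromatic carbon with naphthalen-1-yl in place of 4-methoxyphenyl on an aromatic carbon. Within the data shown here, the only measured step that bears on this, a 1.5-fold lower number from compound 1 to compound 2 (0.18 log units; within the scatter) for methoxy in place of methyl, stays within the scatter, but no measured compound carries naphthalen-1-yl. The expected step is a 1.1-fold higher number from compound 2 to compound 3 (0.05 log units; within the scatter) in this assay and none beyond the scatter is expected. Compound 3 is estimated at 3800 nM with an expected range from 1300 nM to 11000 nM for its measurement.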

Compound 3, half-maximal inhibitory concentration: 3240 nM
The estimate for compound 3 lay 1.2-fold (0.07 log units) above the measured number, within the range that was stated.
By their numbers in this assay, from the lowest: compounds 3, 2 and 1 (each within the scatter of the next).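

In this assay, naphthalen-1-yl in place of 4-methoxyphenyl gives a 1.0-fold lower number from compound 2 to compound 3 (0.02 log units; within the scatter) and naphthalen-1-yl in place of 4-methylphenyl gives a 1.6-fold lower number from compound 1 to compound 3 (0.20 log units; within the scatter). This position therefore carries a group with two six-membered aromatic rings of carbon only and no hydrogen-bond acceptor, with the number still within the scatter of both single-ring compounds. Nothing at hand explains this result. Still open, going by these compounds, is whether any group at this position moves the number beyond the scatter, for example a ring bearing an amine or a carboxylic acid.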